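Tolerated concentration notes, compounds 1 to 4

A few compounds are considered here, and "the series" means these few. Any claim that something is new, unique, unknown or untested is made for them only; others in the source may bear on it.

Measured compounds:
compound 1 `CCN(CC)c1nc(C)c2[nH]c(SCC(=O)NCCN)nc2n1`: > 100 uM, a limit of the assay
compound 2 `CCN(CC)CC[n+]1c(SCC(=O)NCCN)[nH]c2c(C)nc(N(CC)CC)nc21`: 52.2 uM
compound 3 `CCN(CC)c1nc(C)c2[nH]c(SCC(=O)NCCN)[n+](CCCN(C)C)c2n1`: > 100 uM, a limit of the assay

In an ADME assay on CEM174 cells (Homo sapiens) for cytotoxicity (a higher number here means that more compound is tolerated, a lower number that less compound is tolerated), compound 1 gives > 100 uM, which is a limit and not a number. Compound 2 gives 52.2 uM. Compound 3 gives > 100 uM, again a limit. Compound 3 therefore stands at the top of the numbers shown, together with compound 1 (the limit of > 100 uM in this assay, at which 2 of the 3 values shown sit). Compound 4 `CCN(CC)c1nc(C)c2[nH]c(SCC(=O)NCCCNC(=N)N)[n+](CCCN(C)C)c2n1` differs from compound 3 by a group of 5 heavy atoms (2 carbon, 3 nitrogen; no ring) in place of one nitrogen atom, on a saturated chain carbon, two bonds along the chain from an amide-type nitrogen. Within the data shown here, the only measured step, an at least 1.9-fold higher number from compound 2 to compound 3 (0.28 log units; that floor lies within the scatter), concerns the chain on the aromatic nitrogen and runs up to the limit; no measured step touches the chain on the amide-type nitrogen. Compound 4 is thus expected to remain at or near the limit, with a number no higher from compound 3 to compound 4 (the limit leaves the size open) expected to lie within the scatter. The estimate for compound 4 is 100 uM, range 45 uM to 220 uM.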

Compound 4, half-maximal toxic concentration: > 100 uM
Compound 4 was reported as a limit (the forecaster's own chance of this, stated with the estimate: 60%); the middle value sits exactly at the limit.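

In this assay compound 3 and compound 4 both stand at a limit, so no step between them can be read: the limit of > 100 uM in this assay, at which 3 of the 4 values shown sit.

Going by these compounds, whether the group entering at the chain on the amide-type nitrogen changes tolerance at all remains open.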